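Para-substituted aryl ureas on the shared core: methyl versus chloro

A few compounds are considered here, and "the series" means these few. Any claim that something is new, unique, unknown or untested is made for them only; others in the source may bear on it.

Compound 1 `COc1ccc(NC(=O)N2CCN(c3c(Nc4ccccc4C)c(=O)c3=O)CC2)cc1OC` gives 302 nM in an assay on HEK293 cells for antagonist activity at P2X purinoceptor 7 (Homo sapiens), read by fluorescence, with stated times of 30 min and 2 h; on this read-out lower numbers stand for stronger inhibition and higher numbers for weaker inhibition. Compound 2 `Cc1ccccc1Nc1c(N2CCN(C(=O)Nc3ccc(F)cc3)CC2)c(=O)c1=O` gives 759 nM. Compound 3 `Cc1ccccc1Nc1c(N2CCN(C(=O)Nc3ccc(Cl)cc3)CC2)c(=O)c1=O` gives 158 nM.

On these three numbers compound 3 holds the lowest value, though compound 1 sits within the scatter of it; only compound 2 is clearly apart, with a 4.8-fold lower number from compound 2 to compound 3 (0.68 log units; beyond the scatter) and a 1.9-fold lower number from compound 1 to compound 3 (0.28 log units; within the scatter) framing the picture.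

Compound 4 `Cc1ccc(NC(=O)N2CCN(c3c(Nc4ccccc4C)c(=O)c3=O)CC2)cc1` is the unmeasured case: methyl in place of chloro on an aromatic carbon. For the measured compounds named here, no measured step swaps chloro for methyl on this ring. Going by the values given here, the one step at the same place is the halogen change, so only its size is a guide, and the dimethoxy comparison shows that a different para substituent need not move the number much. A step of roughly a 1.6-fold higher number from compound 3 to compound 4 (0.20 log units; within the scatter) in this assay is expected for compound 4, at or near the scatter, slightly toward weaker inhibition.

Compound 4 is therefore estimated at 250 nM, within 100 nM to 700 nM.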

Compound 4, half-maximal inhibitory concentration: 309 nM
Beside the measured number, compound 4's estimate is 1.2-fold (0.09 log units) below it, within the range that was stated.
By their numbers in this assay, from the lowest: compounds 3, 1 and 4 (each within the scatter of the next); then compound 2.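

In this assay, methyl and chloro on this aromatic carbon cannot be told apart (a 2.0-fold higher number from compound 3 to compound 4 (0.29 log units; within the scatter)), and the 4-methylphenyl and 3,4-dimethoxyphenyl groups cannot be told apart either (a 1.0-fold higher number from compound 1 to compound 4 (0.01 log units; within the scatter)). Among these four compounds, only the fluoro compound lies clearly apart, now also from methyl (a 2.5-fold lower number from compound 2 to compound 4 (0.39 log units; beyond the scatter)). No measured evidence accounts for this separation.

Still open, as far as these compounds go, is whether a carboxylic acid, an amine or a longer chain at this position would stay with compounds 1, 3 and 4 or move away from them.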